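The compounds below may be only part of what the source reports. "The series", "measured", "known", "first", "only" and "open" are said of these compounds alone.

The measured compounds:
compound 1, `CCCc1nnc(SCc2ccccc2)n1N1C(=O)c2ccccc2C1=O`
compound 2, `CCCc1nnc(SC)n1N1C(=O)c2ccccc2C1=O`
compound 3, `COc1cc(-c2nnc(SC)n2N2C(=O)c3ccccc3C2=O)cc(OC)c1OC`

In a functional assay on MKN-45 cells (Homo sapiens) for cytotoxicity, read by MTT assay, with a stated time of 48 h (on this read-out lower numbers stand for stronger inhibition and higher numbers for weaker inhibition), compound 2 gives only a limit, > 200000 nM. In this assay compound 1 likewise gives only a limit, > 200000 nM. Compound 3 also reaches only a limit in this assay, > 200000 nM. The change from compound 2 to compound 1 is phenyl in place of hydrogen on a saturated chain carbon bound to a sulfur, and the step it made, a step that the two limits leave unreadable from compound 2 to compound 1, cannot be read because both values sit at the limit of > 200000 nM in this assay, at which 3 of the 3 values shown sit. Compound 4, `COc1cc(-c2nnc(SCc3ccccc3)n2N2C(=O)c3ccccc3C2=O)cc(OC)c1OC`, not yet measured, carries the same change relative to compound 3: phenyl in place of hydrogen on a saturated chain carbon bound to a sulfur. How the core of compound 3 differs from the core of compound 2 is not broken down here. Among the compounds with values here, with every value so far resting at the limit of > 200000 nM in this assay, at which 3 of the 3 values shown sit, compound 4 is expected to show a step that the limit leaves unreadable from compound 3 to compound 4 in this assay, which is to say no readable step at all. Compound 4 is therefore estimated at 300000 nM, with the likeliest outcome being another limit rather than a number.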

Compound 4, half-maximal inhibitory concentration: > 200000 nM
Compound 4 gave a limit, no number; the forecaster's own chance of this, stated with the estimate: 85%; the middle value lies beyond the limit too.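

In this assay compound 4 gives > 200000 nM, which is a limit and not a number. No new step can be read from compound 3 or compound 1 to compound 4, because all the values rest on the same limit: the limit of > 200000 nM in this assay, at which 4 of the 4 values shown sit. The compounds shown leave open whether any compound of this kind would give a number rather than a limit in this assay.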